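From dimethyl to diethyl on a sulfonyl sulfur

This account rests on a few compounds, and the source may have more. Where it says the series, first, only, none or still open, it means among the compounds named here.

Of the compounds shown here, two sharing one core have been tested in a functional assay on NT2 cells (Homo sapiens) for inhibition; a higher number here means a weaker inhibitor, a lower number a stronger inhibitor. Compound 1 `CCCN(CCC)C(=O)c1cncc(C(=O)N[C@@H](CC(=O)O)C(=O)CSCc2ccc(F)cc2)c1` gives > 100000 nM, which is a limit of the assay and not a number. Going by the values given here, compound 2 `CN(C)S(=O)(=O)c1cncc(C(=O)N[C@@H](CC(=O)O)C(=O)CSCc2ccc(F)cc2)c1` gives 21000 nM, the only true number so far.

The next compound is compound 3 `CCN(CC)S(=O)(=O)c1cncc(C(=O)N[C@@H](CC(=O)O)C(=O)CSCc2ccc(F)cc2)c1`, and the change is diethylamino in place of dimethylamino on a sulfonyl sulfur. Among the compounds with values here, only one measured step bears on this: an at least 4.7-fold lower number from compound 1 to compound 2 (0.67 log units; beyond the scatter), with dimethylsulfamoyl in place of dipropylcarbamoyl on an aromatic carbon. That step lies beyond the scatter, but it is a loose guide. As far as these compounds go, it swaps carbamoyl for sulfamoyl as well as changing the chains, and one of its ends is a limit, so its full size is unknown.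

Going by the direction of an at least 4.7-fold lower number from compound 1 to compound 2 (0.67 log units; beyond the scatter), a small move towards a higher number is expected in this assay, possibly no larger than the scatter. The expected step is a 1.5-fold higher number from compound 2 to compound 3 (0.18 log units; within the scatter). For compound 3 the estimate is 32000 nM, with an expected range from 11000 nM to 90000 nM.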

Compound 3, half-maximal inhibitory concentration: 12000 nM
The estimate for compound 3 lay 2.7-fold (0.43 log units) above the measured number; the range from low to high includes it.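

In this assay, the first direct test of this change on the sulfonyl sulfur gives a 1.8-fold lower number from compound 2 to compound 3 (0.24 log units; within the scatter), so diethylamino and dimethylamino cannot be told apart at this place, and the larger group costs nothing that can be detected. Diethylamino also gives a second sulfamoyl compound that stands clear of the dipropylcarbamoyl compound, with an at least 8.3-fold lower number from compound 1 to compound 3 (0.92 log units; beyond the scatter), so the gap seen earlier does not rest on dimethylsulfamoyl alone. The value of compound 1 is a limit and not a number, so the full size of that step stays unknown: the limit of > 100000 nM in this assay, at which 1 of the 3 values shown sits.

The step from the dipropylcarbamoyl compound changes both the carbonyl-to-sulfonyl link and the chains at once, so the compounds shown cannot say which of the two matters, and dipropylamino on the sulfonyl sulfur would separate them. They also leave open whether a longer chain or a ring such as piperidine on the sulfonyl sulfur would move the number beyond the scatter, since the two small groups shown do not.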